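The source may report more compounds than this note shows. Statements on the series, on what has been measured and on what is new or still open speak of the compounds shown alone.

Of the compounds shown here, two built on a shared core have been tested in an assay on Jurkat cells for activation of nuclear factor NF-kappa-B complex (Homo sapiens); a higher number here means a weaker inhibitor, a lower number a stronger inhibitor. Compound 1, `Cc1nc(C(F)(F)F)ncc1C(=O)Nc1cc(C(F)(F)F)cc(C(F)(F)F)c1`, gives > 10000 nM, which is a limit of the assay rather than a measured number. Compound 2, `O=C(Nc1cc(C(F)(F)F)cc(C(F)(F)F)c1)c1cc(C(F)(F)F)nc(Cl)n1`, likewise gives > 10000 nM, again a limit and not a number. For the measured compounds named here, compound 2 therefore stands at the edge of what this assay can report, and the only other measured compound sits at that same edge (the limit of > 10000 nM in this assay, at which 2 of the 2 values shown sit). Compound 3, `O=C(Nc1cc(C(F)(F)F)cc(C(F)(F)F)c1)c1cc(Cl)nc(Cl)n1`, is not yet measured. It differs from compound 2 by one change, chloro in place of trifluoromethyl on an aromatic carbon, next to the ring nitrogen, meta to a chloro group and opposite the ring nitrogen. Going by the values given here, no measured step between any two compounds here shows what such a swap does to potency, so the step from compound 2 to compound 3 is expected to be none beyond the scatter, a step that the limit leaves unreadable from compound 2 to compound 3. Compound 3 is accordingly estimated at about 15000 nM, within a range of 4000 nM to 60000 nM, most likely reported again only as a limit.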

Compound 3, half-maximal inhibitory concentration: > 10000 nM
Compound 3 gave a limit, no number (the forecaster's own chance of this, stated with the estimate: 85%); the middle value lies beyond the limit too.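

No step can be read from compound 2 to compound 3, since both give only a limit and not a number in this assay: the limit of > 10000 nM in this assay, at which 3 of the 3 values shown sit. The compounds shown leave open how chloro and trifluoromethyl compare at this place, and whether any compound on the shared core gives a measured number in this assay.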